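Trimming a Methyl from the Most Potent Compound

The source may report more compounds than this note shows. Statements on the series, on what has been measured and on what is new or still open speak of the compounds shown alone.

Measured so far:
compound 2 `COc1cc(C(=O)c2sc(Nc3ccc(C)cc3)nc2N)cc(OC)c1OC` — 41 nM
compound 1 `COc1ccc(C(=O)c2sc(Nc3ccccc3)nc2N)cc1OC` — 6900 nM
compound 3 `COc1ccc(C(=O)c2sc(Nc3ccc(Cl)cc3)nc2N)cc1` — a limit of the assay, > 10000 nM

In a functional assay on CCRF-CEM cells (Homo sapiens) for antiproliferative activity, read by cell counting, with a stated time of 2 days (a higher number here means a weaker inhibitor, a lower number a stronger inhibitor), compound 2 gives 41 nM, the lowest of the two numbers shown. Compound 1 gives 6900 nM, a far higher number, beyond the scatter. For compound 3 the assay reports only a limit, > 10000 nM, not a number.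

Compound 4 `COc1cc(C(=O)c2sc(Nc3ccccc3)nc2N)cc(OC)c1OC` differs from compound 2 in one place: hydrogen in place of methyl on an aromatic carbon. Among the compounds with values here, no pair of measured compounds differs by exactly this change, so its effect is not yet known. Compound 4 is expected to give a somewhat higher number than compound 2, with the step of a 2.4-fold higher number from compound 2 to compound 4 (0.39 log units; beyond the scatter) expected to be small, perhaps only just beyond the scatter. Compound 4 is estimated at 100 nM, between 30 nM and 400 nM.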

Compound 4, half-maximal inhibitory concentration: 9.4 nM
For compound 4 the middle estimate is 11-fold (1.03 log units) above the measured one; measured number outside the range, below it.
By their numbers in this assay, from the lowest: compound 4; then compound 2; then compound 1. At a limit, above all of these: compound 3.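

In this assay, the methyl para to a large group proves dispensable: changing 4-methylphenyl to phenyl gives a 4.4-fold lower number from compound 2 to compound 4 (0.64 log units; beyond the scatter), so hydrogen at this position gives the stronger inhibitor in this pair. A single methoxy in place of hydrogen on an aromatic carbon matters far more, giving a 730-fold lower number from compound 1 to compound 4 (2.87 log units; beyond the scatter). Nothing shown bears on the cause of either step.

On these data alone, what an amine, a carboxylic acid or a longer chain would do in place of that methyl remains open. As far as these compounds go, whether a methyl costs as much on the core of compound 1 also remains open.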